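The source may hold more compounds than are shown below. What is called first, only, known or untested is meant among the compounds shown, and "the series" means these compounds.

The measured compounds:
Compound 1, `Cc1ccc(CS/C(=C/c2ccc(C)s2)C(=O)c2ccc(Cl)cc2)cc1`, gives 50000 nM in a functional assay on DU-145 cells (Homo sapiens) for inhibition, read by trypan blue exclusion, with a stated time of 96 h; a higher number here means a weaker inhibitor of growth, a lower number a stronger inhibitor of growth.
Compound 2, `Cc1ccc(CS/C(=C/c2c[nH]c3ccc(Cl)cc23)C(=O)c2ccc(Cl)cc2)cc1`, gives 1000 nM in this assay.
Compound 3, `COc1ccccc1/C=C(/Sc1ccc(C)cc1)C(=O)c1ccc(Cl)cc1`, gives 25000 nM in this assay.

Compound 3 stands second highest of the three numbers. Its value and that of compound 1 lie within the scatter of each other, while compound 2 sits well below both. Within the data shown here, the only measured step, a 50-fold lower number from compound 1 to compound 2 (1.70 log units; beyond the scatter), changed the group on the chain carbon and left the sulfur substituent alone, so it says nothing about the change now in question. Compound 4, `COc1ccccc1/C=C(/SCc1ccc(C)cc1)C(=O)c1ccc(Cl)cc1`, differs from compound 3 in one place: 4-methylbenzyl in place of 4-methylphenyl on a sulfur. Among the measured compounds shown here, no measured pair shows what this exchange on the sulfur does in this assay; compounds 1 and 2 carry the entering group and compound 3 the leaving group, but they differ elsewhere as well, so no step can be read from them. With nothing to point either way, compound 4 is expected to show a step of no change at the digits printed from compound 3 to compound 4 (within the scatter), within the scatter. The estimate for compound 4 in this assay is 25000 nM, between 8000 nM and 70000 nM.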

Compound 4, concentration for 50% growth inhibition: 10000 nM
Compound 4: middle estimate off by 2.5-fold (0.40 log units), on the high side; the range from low to high includes it.
By their numbers in this assay, from the lowest: compound 2; then compound 4; then compounds 3 and 1 (each within the scatter of the next).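

In this assay, the sulfur position now has a reading of its own: 4-methylbenzyl in place of 4-methylphenyl on a sulfur gives a 2.5-fold lower number from compound 3 to compound 4 (0.40 log units; beyond the scatter), so this one exchange moves the number beyond the scatter. With 4-methylbenzyl on the sulfur in each pair, compound 4 also places 2-methoxyphenyl on the chain carbon, with a 10-fold higher number from compound 2 to compound 4 (1.00 log units; beyond the scatter) and a 5.0-fold lower number from compound 1 to compound 4 (0.70 log units; beyond the scatter), so among these three groups the number is lowest with 5-chloro-1H-indol-3-yl and highest with 5-methylthiophen-2-yl. No available measurement bears on why the sulfur exchange has this effect.

On these data alone, it remains open whether the same exchange gives a similar step with 5-chloro-1H-indol-3-yl or 5-methylthiophen-2-yl on the chain carbon. As far as these compounds go, it is also open whether a longer chain on the sulfur, such as 2-(4-methylphenyl)ethyl, would lower the number further.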